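A Methoxy Step and the Expected Tolerance of Compound 4

This account rests on a few compounds, and the source may have more. Where it says the series, first, only, none or still open, it means among the compounds named here.

In an ADME assay on THP-1 cells (Homo sapiens) for cytotoxicity, read by MTT assay (a lower number here means that less compound is tolerated, a higher number that more compound is tolerated), compound 1 `COc1cccc(/C=C/C(=O)c2ccccc2O)c1` gives > 25000 nM, which is a limit of the assay and not a number. Compound 2 `COc1ccc(O)c(C(=O)/C=C/c2ccc(OC)c(OC)c2)c1` gives > 50000 nM in this assay, again only a limit. Compound 3 `COc1ccc(/C=C/C(=O)c2cc(OC)ccc2O)cc1` gives > 100000 nM, likewise a limit. The difference between the cores of compound 1 and compound 3 is not broken down here. From compound 3 to compound 2 the change is methoxy in place of hydrogen on an aromatic carbon, and the step that the two limits leave unreadable from compound 3 to compound 2 cannot be read because the limit of > 100000 nM in this assay, at which 1 of the 3 values shown sits, and the limit of > 50000 nM in this assay, at which 1 of the 3 values shown sits, both sit at limits of the assay.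

Compound 4 `COc1cccc(/C=C/C(=O)c2ccc(OC)cc2O)c1` is not yet measured. It arises from compound 1 by methoxy in place of hydrogen on an aromatic carbon, the same kind of change, though the surroundings differ: here the methoxy enters meta to a hydroxy group and para to a large group, whereas in the measured pair it entered ortho to a methoxy group and meta to a large group. In this assay the expected step is a step that the limit leaves unreadable from compound 1 to compound 4, which rests on the limit given by compound 1 > 25000 nM and on (the limit of > 25000 nM in this assay, at which 1 of the 3 values shown sits). Compound 4 is therefore expected to give 60000 nM, with a range from 20000 nM to 200000 nM.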

Compound 4, half-maximal cytotoxic concentration: > 25000 nM
Compound 4 gave a limit, no number (the forecaster's own chance of this, stated with the estimate: 75%); the middle value is on the limit's open side.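

The step from compound 1 to compound 4 cannot be read, as both compounds stand at the same limit of the assay in this assay: the limit of > 25000 nM in this assay, at which 2 of the 4 values shown sit.

The compounds shown leave open whether methoxy in place of hydrogen on an aromatic carbon changes tolerance at all in this assay, and at what concentration any of them would become cytotoxic.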